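This account rests on a few compounds, and the source may have more. Where it says the series, first, only, none or still open, it means among the compounds named here.

Measured in a functional assay on K562 cells (Homo sapiens) for cytotoxicity, read by MTT assay; a higher number here means a weaker inhibitor, a lower number a stronger inhibitor:
- Compound 1 `C#CCOc1cc(/C=C/C(=O)c2ccc(OC)c3c2OC(C)(C)C=C3)ccc1OC`: > 10000 nM
- Compound 2 `COc1ccc(/C=C/C(=O)c2ccc(OC)c3c2OC(C)(C)C=C3)cc1OC(=O)C(C)C`: 570 nM

The result for compound 1 is a limit of the assay, not a number: the limit of > 10000 nM in this assay, at which 1 of the 2 values shown sits.

Among the compounds with values here, compound 2, at 570 nM, therefore holds the only numerical value in this assay.

Compound 3 `C=CC(=O)Oc1cc(/C=C/C(=O)c2ccc(OC)c3c2OC(C)(C)C=C3)ccc1OC` has vinyl in place of isopropyl on a carbonyl carbon. Within the data shown here, the one measured step, an at least 17-fold lower number from compound 1 to compound 2 (1.24 log units; beyond the scatter), is large, but it replaces propargyl with isopropylcarbonyl on an oxygen on an aromatic ring. Compound 3 keeps a carbonyl there, so it is expected to remain on the active side of that large step. Among the measured compounds shown here, no measured step covers the exchange of isopropyl for vinyl, so only a small change in this assay is expected, with no firm direction. The expected step is a 1.3-fold lower number from compound 2 to compound 3 (0.10 log units; within the scatter). For compound 3, the estimated value is 450 nM, with an expected range from 130 nM to 1800 nM.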

Compound 3, half-maximal inhibitory concentration: 300 nM
Compound 3: the middle estimate sits 1.5-fold (0.18 log units) above what was measured, within the range that was stated.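

In this assay, vinyl in place of isopropyl on a carbonyl carbon gives a 1.9-fold lower number from compound 2 to compound 3 (0.28 log units; within the scatter), so this exchange does not separate the two compounds. The step from propargyl to vinylcarbonyl on the same oxygen is an at least 33-fold lower number from compound 1 to compound 3 (1.52 log units; beyond the scatter), which shows that the large step seen with isopropylcarbonyl is not confined to that one group and recurs with a second, smaller group on the carbonyl. The result for compound 1 remains a limit of the assay, not a number: the limit of > 10000 nM in this assay, at which 1 of the 3 values shown sits.

From the compounds shown here alone, what a longer chain or an amine on that carbonyl carbon would do in this assay remains open. With propargyl as the only group shown without a carbonyl, the compounds also leave open how a free hydroxyl or a simple methyl on that oxygen would compare.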